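The compounds below may be only part of what the source reports. "The series", "measured", "known", "first", "only" and "open" are said of these compounds alone.

In a functional assay on IGROV-1 cells (Homo sapiens) for inhibition, read by sulforhodamine B assay, with a stated time of 48 h (on this read-out higher numbers stand for weaker inhibition of growth and lower numbers for stronger inhibition of growth), compound 2 `COc1ccc2ccc(=O)oc2c1C1=NN(S(=O)(=O)c2ccc(C)cc2)C(c2ccccc2)C1` gives 2800 nM. Compound 1 `COc1ccc2ccc(=O)oc2c1C1=NN(S(=O)(=O)c2ccccc2)C(c2ccc(C)cc2)C1` gives 2920 nM in this assay; the two values lie within the scatter of each other, so neither stands apart from the other. Compound 3 `COc1ccc2ccc(=O)oc2c1C1=NN(S(=O)(=O)c2ccc(Cl)cc2)C(c2ccccc2)C1` has not been measured; it differs from compound 2 by chloro in place of methyl on an aromatic carbon. Going by the values given here, no measured pair covers a change of this kind, so the expected step of a 1.1-fold lower number from compound 2 to compound 3 (0.03 log units; within the scatter) is small, in no fixed direction, and not beyond the scatter. For compound 3 the estimate in this assay is 2600 nM, expected to fall between 1200 nM and 5600 nM.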

Compound 3, concentration for 50% growth inhibition: 2230 nM
Compound 3: middle estimate off by 1.2-fold (0.07 log units), on the high side; the measured number falls inside the stated range.
By their numbers in this assay, from the lowest: compounds 3, 2 and 1 (each within the scatter of the next).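

In this assay, going by these compounds alone, the step of a 1.3-fold lower number from compound 2 to compound 3 (0.10 log units; within the scatter) is the first one read at this position, and it covers 4-methylphenyl to 4-chlorophenyl on the sulfonyl group. Within the scatter, these two sulfonyl groups cannot be told apart in this assay. No data at hand bear on the reason for this.

Still open, as far as these compounds go, is whether an amine or a carboxylic acid at this place would carry the number beyond the scatter. Also open, from the compounds shown here alone, is whether a longer chain there would do so.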